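Carboxyphenyl placement on a furan-linked trimethoxybenzohydrazide series

The compounds below may be only part of what the source reports. "The series", "measured", "known", "first", "only" and "open" are said of these compounds alone.

Measured compounds:
compound 1 `COc1cc(C(=O)N/N=C/c2ccc(-c3cccc(C(=O)O)c3)o2)cc(OC)c1OC` — 38000 nM
compound 2 `COc1cc(C(=O)N/N=C/c2c[nH]c(-c3cccc(C(=O)O)c3)c2)cc(OC)c1OC` — 80000 nM
compound 3 `COc1cc(C(=O)N/N=C/c2cccc(-c3cccc(C(=O)O)c3)n2)cc(OC)c1OC` — "not determined" (no result reported)

In a functional assay on Raji cells (Homo sapiens) for antiproliferative activity, read by trypan blue exclusion, with a stated time of 24 h (a lower number here means a stronger inhibitor, a higher number a weaker inhibitor), compound 1 gives 38000 nM, the lowest of the two numbers available. Compound 2 gives 80000 nM, a higher number that lies beyond the usual scatter. For compound 3 the entry reads "not determined" (no result reported), so no number is available for it.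

Compound 4 `COc1cc(C(=O)N/N=C/c2ccc(-c3ccc(C(=O)O)cc3)o2)cc(OC)c1OC` differs from compound 1 by one change: 4-carboxyphenyl in place of 3-carboxyphenyl on an aromatic carbon. Within the data shown here, no measured pair in this set shows what such a change does, so there is no step to lean on. The step of a 1.1-fold higher number from compound 1 to compound 4 (0.02 log units; within the scatter) is expected to be small, with no direction beyond the scatter. Compound 4 is therefore expected to give 40000 nM, with a range from 15000 nM to 100000 nM.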

Compound 4, half-maximal inhibitory concentration: 100000 nM
The estimate for compound 4 lay 2.5-fold (0.40 log units) below the measured number; measured number inside the range.
By their numbers in this assay, from the lowest: compound 1; then compounds 2 and 4 (each within the scatter of the next).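

In this assay, 4-carboxyphenyl in place of 3-carboxyphenyl gives a 2.6-fold higher number from compound 1 to compound 4 (0.42 log units; beyond the scatter). Among these compounds, this is the only measured step at this place, on an aromatic carbon next to the ring oxygen, and it shows that the number changes with the attachment of the carboxylic acid on the phenyl ring alone, with the same atoms present. Nothing measured here accounts for this step.

The compounds shown leave open how a methyl ester or a tetrazole in place of the carboxylic acid would read at this place. They also leave open whether the same change would give a similar step on the core of compound 2.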